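From compound 2 to compound 3: a smaller ring group

The source may report more compounds than this note shows. Statements on the series, on what has been measured and on what is new or still open speak of the compounds shown alone.

Among the compounds with values here, in an ADME assay on microsomes from liver (Rattus norvegicus) for metabolic stability, read by LC-MS, using NADPH, at 37 degrees C (on this read-out higher numbers stand for a longer-lived compound and lower numbers for a shorter-lived compound), compound 1 `Cc1ccccc1-c1nc(CN2CCC(C(=O)NCCCN3CCC(C(C)C)CC3)CC2)c(C)o1` gives 0.147 h and compound 2 `Cc1ccccc1-c1nc(CN2CCC(C(=O)NCCCN3CCCC(CC(C)C)C3)CC2)c(C)o1` gives 0.0383 h, so compound 2 holds the lower of the two numbers known so far. Compound 3 `Cc1ccccc1-c1nc(CN2CCC(C(=O)NCCN3C[C@H](C)C[C@H](C)C3)CC2)c(C)o1` has not yet been measured. Its difference from compound 2 is this: a group of 8 heavy atoms (7 carbon, 1 nitrogen; one six-membered non-aromatic ring with 1 hetero atom) in place of a group of 11 heavy atoms (10 carbon, 1 nitrogen; one six-membered non-aromatic ring with 1 hetero atom), on a saturated chain carbon, two bonds along the chain from an amide-type nitrogen. The entering 3,5-dimethylpiperidin-1-yl group sits on a saturated chain carbon, two bonds along the chain from an amide-type nitrogen. Within the data shown here, the one measured step that bears on this, a 3.8-fold lower number from compound 1 to compound 2 (0.58 log units; beyond the scatter), came with a larger group entering, so with a smaller group entering here a move of similar size in the opposite direction is expected, an estimated 2.9-fold higher number from compound 2 to compound 3 (0.46 log units; beyond the scatter) in this assay. Among the measured compounds shown here, this rests on a single pair, and no measured compound carries the entering group, so the range is kept wide. Compound 3 is estimated at 0.11 h, with an expected range of 0.045 h to 0.28 h.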

Compound 3, half-life: > 0.5 h
Compound 3 was reported as a limit; the forecaster's own chance of this, stated with the estimate: 3%; at least 4.5-fold (0.65 log units) between middle value and limit.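

In this assay, the exchange of the larger ring group for 3,5-dimethylpiperidin-1-yl on a saturated chain carbon, two bonds along the chain from an amide-type nitrogen, brought an at least 13-fold higher number from compound 2 to compound 3 (1.11 log units; beyond the scatter). The new group also carried the half-life past that of the longer-lived earlier compound, with an at least 3.4-fold higher number from compound 1 to compound 3 (0.53 log units; beyond the scatter), so this position can move the read-out strongly upward, whereas the only earlier step, a 3.8-fold lower number from compound 1 to compound 2 (0.58 log units; beyond the scatter), had shown a fall. The reading for compound 3 is a limit of the assay and not a number: the limit of > 0.5 h in this assay, at which 1 of the 3 values shown sits.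

From the compounds shown here alone, how far compound 3 lies beyond that limit stays open, and both steps give only a lower bound on the size of the change. Also open, going by these compounds, is how much of the rise belongs to the two methyl groups on the ring, and whether a plain piperidin-1-yl or a morpholin-4-yl group in the same place, or the other stereoisomers of the 3,5-dimethylpiperidin-1-yl group, would give a similar half-life.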